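Benzyl Ether Step on a Pyridyl Thiazole Core

The compounds below may be only part of what the source reports. "The series", "measured", "known", "first", "only" and "open" are said of these compounds alone.

Measured compounds:
compound 1, `CCOC(=O)c1sc(-c2ccccc2)nc1N1CCC(NCc2ccc(OC)cc2)CC1`, 8.4%
compound 2, `CCOC(=O)c1sc(-c2ccccc2)nc1N1CCC(NCc2ccc(OCc3ccccc3)cc2)CC1`, 18.4%
compound 3, `CCOC(=O)c1sc(-c2ccccn2)nc1N1CCC(NCc2ccc(OC)cc2)CC1`, 4.62%

The values above come from an ADME assay on RAW264.7 cells (Mus musculus) for cytotoxicity, read by MTT assay, with a stated time of 72 h, tested at 50 uM; a higher number here means more inhibition at the concentration tested (going by the name of the read-out), a lower number less inhibition. Compound 2 differs from compound 1 by phenyl in place of hydrogen on a saturated chain carbon bound to an oxygen on an aromatic ring; in this assay that change gave a number 10 percentage points higher from compound 1 to compound 2 (within the scatter). Compound 3 differs from compound 1 in the core by pyridin-2-yl in place of phenyl on an aromatic carbon, and this gave a number 3.8 percentage points lower from compound 1 to compound 3 (within the scatter). Compound 4, `CCOC(=O)c1sc(-c2ccccn2)nc1N1CCC(NCc2ccc(OCc3ccccc3)cc2)CC1`, has not been measured; it differs from compound 3 by phenyl in place of hydrogen on a saturated chain carbon bound to an oxygen on an aromatic ring, which is the same change made from compound 1 to compound 2, on the same place. For compound 4 a step like a number 9.9 percentage points higher from compound 3 to compound 4 (within the scatter) is expected, resting on the step seen as a number 10 percentage points higher from compound 1 to compound 2 (within the scatter) and on the value of compound 3 as 4.62%. Compound 4 is therefore estimated at 14.5%, within 4% to 26%.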

Compound 4, a percentage reported as inhibition, at one concentration (the size of the read-out at that concentration, not a potency): 12.8%
Compound 4: the middle estimate sits 1.7 percentage points above what was measured; measured number inside the range.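

In this assay, the change from methoxy to benzyloxy gave a number 8.2 percentage points higher from compound 3 to compound 4 (within the scatter), which agrees with the same change on the other core: the same change on two cores in this assay, a number 10 percentage points higher (within the scatter) from compound 1 to compound 2 and a number 8.2 percentage points higher (within the scatter) from compound 3 to compound 4, 1.8 percentage points apart, within the scatter of two such steps. Pyridin-2-yl in place of phenyl gave a number 5.6 percentage points lower from compound 2 to compound 4 (within the scatter), which also agrees with its earlier step: the same change on two cores in this assay, a number 3.8 percentage points lower (within the scatter) from compound 1 to compound 3 and a number 5.6 percentage points lower (within the scatter) from compound 2 to compound 4, 1.8 percentage points apart, within the scatter of two such steps. Across these four compounds the two changes therefore carry from one core to the other without a discernible difference, but every step lies within the scatter, so this does not show that either change has a real effect, or that it would carry to other cores.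

The compounds shown leave open how a cyclohexyl group in place of the phenyl would read. They also leave open how a carboxylic acid or an amide in place of the ethyl ester would read.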